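Chain change from compound 3 to compound 4

This account rests on a few compounds, and the source may have more. Where it says the series, first, only, none or still open, it means among the compounds named here.

In a functional assay on FaDu cells (Homo sapiens) for cytotoxicity, read by MTT assay, with a stated time of 72 h (on this read-out lower numbers stand for higher toxicity in this test and higher numbers for lower toxicity in this test), compound 3 (`COC(=O)CCn1cc(C(=O)C(=O)Nc2ccc(OC)nc2)c2ccccc21`) gives 168 nM, the lowest number shown. Compound 1 (`CCn1cc(C(=O)C(=O)Nc2ccnc(OC)c2)c2ccccc21`) gives a higher 4180 nM in this assay. Compound 2 (`CCn1cc(C(=O)C(=O)Nc2ccncc2)c2ccccc21`) reads > 10000 nM, which is a limit.

Compound 4 (`COc1ccc(NC(=O)C(=O)c2cn(CCOC(C)C)c3ccccc23)cn1`) has isopropoxy in place of methoxycarbonyl on a saturated chain carbon, two bonds along the chain from an aromatic nitrogen.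

Among the compounds with values here, the only measured step (an at least 2.3-fold higher number from compound 1 to compound 2 (0.37 log units; beyond the scatter)) is hydrogen in place of methoxy on an aromatic carbon, and it rests on (the limit of > 10000 nM in this assay, at which 1 of the 3 values shown sits). It does not touch this chain, so it gives no direct guide to size or direction. A modest rise in this assay is expected, with little support. The expected step is a 1.8-fold higher number from compound 3 to compound 4 (0.25 log units; within the scatter). Compound 4 is estimated at 300 nM, with a range from 60 nM to 1500 nM (expected, not measured).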

Compound 4, concentration lethal to 50% of the cells: 211 nM
Compound 4: middle estimate off by 1.4-fold (0.15 log units), on the high side, and the stated range covers the measured number.
By their numbers in this assay, from the lowest: compounds 3 and 4 (each within the scatter of the next); then compound 1. At a limit, above all of these: compound 2.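

Working note on the chain position: with isopropoxy in place of methoxycarbonyl, this assay gives a 1.3-fold higher number from compound 3 to compound 4 (0.10 log units; within the scatter), so the two chains cannot be told apart in this test. Methoxycarbonyl is therefore not needed at this position for a number in this range, and an ether chain of the same heavy-atom count serves equally well here. Nothing measured in this set bears on why the two groups read alike.

Still open, as far as these compounds go, is how far this tolerance extends. A carboxylic acid or an amine at the end of this chain could read quite differently, and the same holds for a longer chain.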